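The source may hold more compounds than are shown below. What is called first, only, known or untested is meant among the compounds shown, and "the series" means these compounds.

Compound 3, `Cc1c(O)cc(CCCCC(C)(C)O)oc1=O`, is the starting point of this step. In a functional assay on HeLa cells (Homo sapiens) for cytotoxicity, read by MTT assay (a lower number here means a stronger inhibitor, a higher number a weaker inhibitor), compound 3 gives > 200000 nM, which is a limit of the assay and not a measured number. Two neighbours differ from it in one place. Compound 1, `Cc1c(O)cc(CCCCC(C)[C@H](C)O)oc1=O`, carries 2-hydroxy-1-methylpropyl where compound 3 carries 1-hydroxy-1-methylethyl. In this assay compound 1 gives > 200000 nM, again a limit. Compound 2, `COc1cc(CCCCC(C)(C)O)oc(=O)c1C`, carries methyl in place of hydrogen on an oxygen on the aromatic ring. In this assay compound 2 gives > 200000 nM, also a limit. The steps a step that the two limits leave unreadable from compound 1 to compound 3 and a step that the two limits leave unreadable from compound 2 to compound 3 therefore have no readable size, since (the limit of > 200000 nM in this assay, at which 3 of the 3 values shown sit). Compound 4, `Cc1c(O)cc(CCCCC(C)C)oc1=O`, differs from compound 3 by hydrogen in place of hydroxy on a saturated chain carbon bound to three saturated chain carbons. Within the data shown here, no measured step covers this change, so the expected step that the limit leaves unreadable from compound 3 to compound 4 rests on nothing firmer than three values that all sit at a limit. Compound 4 is estimated at 250000 nM, within a range from 80000 nM to 800000 nM, and is expected most likely to be reported once more as a limit.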

Compound 4, half-maximal inhibitory concentration: > 200000 nM
Compound 4: only a limit was reported; the forecaster's own chance of this, stated with the estimate: 80%; the middle value does not contradict the limit.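

Like compound 3 and compound 1, compound 4 reaches only a limit in this assay, so neither the step from compound 3 to compound 4 nor the one from compound 1 to compound 4 can be read: the limit of > 200000 nM in this assay, at which 4 of the 4 values shown sit. These four compounds leave open whether any of their differences changes activity in this assay at all.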